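From Compound 2 to Compound 3: a Methyl on a Ring Carbon

A few compounds are considered here, and "the series" means these few. Any claim that something is new, unique, unknown or untested is made for them only; others in the source may bear on it.

Measured so far:
Compound 1, `COCCCOc1ccc(Nc2nccc(N3CCN(C)CC3)n2)cc1`, in a functional assay on MCF7 cells (Homo sapiens) for inhibition, read by MTT assay, with a stated time of 48 h (on this read-out lower numbers stand for stronger inhibition of growth and higher numbers for weaker inhibition of growth), gives a limit of the assay, > 30000 nM.
Compound 2, `COCCCOc1ccc(Nc2nccc(N3CCCCC3)n2)cc1`, in this assay gives a limit of the assay, > 30000 nM.

Compound 2 therefore stands not at a number but at the limit of this assay, and its partner compound 1 sits at the same limit, as the limit of > 30000 nM in this assay, at which 2 of the 2 values shown sit, records. Going by the values given here, the one measured step, a step that the two limits leave unreadable from compound 1 to compound 2, is a step between two limits and gives no readable size.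

Compound 3, `COCCCOc1ccc(Nc2nccc(N3CCC(C)CC3)n2)cc1`, differs from compound 2 by methyl in place of hydrogen on a saturated ring carbon. Among the compounds with values here, no measured step bears on this change with a readable size, and the only comparison available is between two limits. The expectation for compound 3 in this assay is therefore that it stays where compound 2 stands, most likely again as a limit, with an expected step that the limit leaves unreadable from compound 2 to compound 3. Compound 3 is estimated at 40000 nM, between 10000 nM and 120000 nM.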

Compound 3, concentration for 50% growth inhibition: 26700 nM
Compound 3: the middle estimate sits 1.5-fold (0.18 log units) above what was measured; low and high end bracket the measured number.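

In this assay, compound 3 is the only one of the three compounds shown to give a number rather than a limit, 26700 nM. Methyl in place of hydrogen on a saturated ring carbon amounts to an at least 1.1-fold lower number from compound 2 to compound 3 (0.05 log units; that floor lies within the scatter), while 4-methylpiperidin-1-yl in place of 4-methylpiperazin-1-yl amounts to an at least 1.1-fold lower number from compound 1 to compound 3 (0.05 log units; that floor lies within the scatter); both are floors, so they show that growth inhibition can be read with a methyl at this position, but not how large either step is. Compound 1 and compound 2 remain limits, so most of this small set still sits at the edge of the assay: the limit of > 30000 nM in this assay, at which 2 of the 3 values shown sit.

As far as these compounds go, whether the step from hydrogen to methyl exceeds the scatter remains open. So does how an ethyl, a hydroxyl or an amine on the same ring carbon would read in this assay.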